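A few compounds are considered here, and "the series" means these few. Any claim that something is new, unique, unknown or untested is made for them only; others in the source may bear on it.

Of the compounds shown here, three built on one shared core have been measured in a functional assay on A549 cells (Homo sapiens) for inhibition, read by MTT assay, with a stated time of 72 h; a lower number here means a stronger inhibitor, a higher number a weaker inhibitor. Compound 1 `CN(C(=O)NC(=O)c1ccc(F)c(F)c1)c1nc(C(F)(F)F)c(C(=O)N/N=C/c2ccc(C(F)(F)F)cc2)s1` gives 6.07 ug/mL. Compound 2 `CN(C(=O)NC(=O)c1ccc(Cl)cc1Cl)c1nc(C(F)(F)F)c(C(=O)N/N=C/c2cccc(C(F)(F)F)c2)s1` gives 10.6 ug/mL. Compound 3 `CN(C(=O)NC(=O)c1ccc(F)c(F)c1)c1nc(C(F)(F)F)c(C(=O)N/N=C/c2cc(C(F)(F)F)cc(C(F)(F)F)c2)s1` gives 5.47 ug/mL, the lowest of the three numbers; its gaps to compound 1 and to compound 2 both lie within the usual scatter of repeated measurements, so no order among the three can be claimed.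

Compound 4 `CN(C(=O)NC(=O)c1ccc(F)c(F)c1)c1nc(C(F)(F)F)c(C(=O)N/N=C/c2cccc(C(F)(F)F)c2)s1` has not yet been measured in this assay. The change from compound 3 to compound 4 is hydrogen in place of trifluoromethyl on an aromatic carbon. Within the data shown here, no measured pair in this set differs in only one place, so no measured step can guide this one. Because compound 1 gives 6.07 ug/mL and compound 2 gives 10.6 ug/mL, all three numbers cluster closely, and a change of this kind is expected to stay within that cluster. The expected step is a 1.2-fold higher number from compound 3 to compound 4 (0.07 log units; within the scatter), not beyond the scatter. Compound 4 is expected to give 6.5 ug/mL, within a range from 3.2 ug/mL to 13 ug/mL.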

Compound 4, half-maximal inhibitory concentration: 6.52 ug/mL
Compound 4: middle estimate off by 1.0-fold (0.00 log units), on the low side, within the range that was stated.
By their numbers in this assay, from the lowest: compounds 3, 1, 4 and 2 (each within the scatter of the next).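

In this assay the set now has its first steps that differ in one place, and hydrogen in place of trifluoromethyl on this aromatic carbon gives a 1.2-fold higher number from compound 3 to compound 4 (0.08 log units; within the scatter) and so shows no difference that can be told from the scatter. Likewise, 3-(trifluoromethyl)phenyl in place of 4-(trifluoromethyl)phenyl gives a 1.1-fold higher number from compound 1 to compound 4 (0.03 log units; within the scatter) and shows that, among these two compounds, where the trifluoromethyl group sits on that ring cannot be told apart in this assay. On the other side of the molecule, 3,4-difluorophenyl in place of 2,4-dichlorophenyl gives a 1.6-fold lower number from compound 2 to compound 4 (0.21 log units; within the scatter) and also stays inside the scatter.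

On these data alone, whether an amine or a carboxylic acid on this aromatic carbon would stay equally close remains open. Nothing at hand explains why these steps are so small.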